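A few compounds are considered here, and "the series" means these few. Any claim that something is new, unique, unknown or untested is made for them only; others in the source may bear on it.

Measured so far in a functional assay on PANC-1 cells (Homo sapiens) for antiproliferative activity, read by MTT assay, with a stated time of 48 h; on this read-out higher numbers stand for weaker inhibition and lower numbers for stronger inhibition
- compound 1 `COc1ccc(-c2c(Nc3cccc(C(F)(F)F)c3)c3ccccc3oc2=O)cc1` gives 49100 nM
- compound 2 `CCOc1ccc(Nc2c(-c3ccc(OC)cc3)c(=O)oc3cc(OC)ccc23)cc1` gives 36100 nM
- compound 3 `COc1ccc(-c2c(Nc3ccc(C)cc3)c3ccc(OC)cc3oc2=O)cc1` gives 76500 nM

Compound 3 and compound 1 lie within the scatter of each other at the upper end of these numbers, and compound 2 sits lower, with a 2.1-fold higher number from compound 2 to compound 3 (0.33 log units; beyond the scatter) beyond the scatter. Compound 4 `COc1ccc(-c2c(Nc3cccc(C(F)(F)F)c3)c3ccc(OC)cc3oc2=O)cc1` has 3-(trifluoromethyl)phenyl in place of 4-methylphenyl on a nitrogen on an aromatic ring. For the measured compounds named here, the one measured step, a 2.1-fold higher number from compound 2 to compound 3 (0.33 log units; beyond the scatter), is modest and involves a different pair of groups. Compound 1 also carries 3-(trifluoromethyl)phenyl and gives 49100 nM in this assay, so only a small shift is expected. The estimated step is a 1.4-fold lower number from compound 3 to compound 4 (0.14 log units; within the scatter) and no change beyond the scatter is expected. Compound 4 is estimated at 55000 nM, with an expected range from 25000 nM to 110000 nM in this read-out.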

Compound 4, half-maximal inhibitory concentration: 39500 nM
Compound 4: middle estimate off by 1.4-fold (0.14 log units), on the high side; the measured number falls inside the stated range.
By their numbers in this assay, from the lowest: compounds 2, 4, 1 and 3 (each within the scatter of the next, the first and the last beyond it).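

In this assay, the change to 3-(trifluoromethyl)phenyl on the nitrogen gives a 1.9-fold lower number from compound 3 to compound 4 (0.29 log units; within the scatter), and the change from 4-ethoxyphenyl at the same place gives a 1.1-fold higher number from compound 2 to compound 4 (0.04 log units; within the scatter). Compound 4 therefore lies within the scatter of both compound 2 and compound 3, although those two lie beyond the scatter of each other. At the other varied place, methoxy in place of hydrogen on an aromatic carbon gives a 1.2-fold lower number from compound 1 to compound 4 (0.09 log units; within the scatter).

No measurement is available that bears on the reason for these steps. As far as these compounds go, whether a phenyl carrying an amine or a carboxylic acid on that nitrogen would move the number beyond the scatter remains open.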